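The compounds below may be only part of what the source reports. "The series", "measured", "known", "first", "only" and "open" are said of these compounds alone.

Going by the values given here, compound 1 `Cc1cc(NC(=O)Nc2ncccc2C)c2ccccc2n1` is one of three compounds measured in an ADME assay for permeability, using PAMPA, at pH 7.4; on this read-out lower numbers stand for lower permeability and higher numbers for higher permeability. In this assay compound 1 gives 369 10^-6 cm/s, the second highest of the three numbers. Compound 3 `COc1cccc(NC(=O)Nc2cc(C)nc3ccccc23)c1` gives 818 10^-6 cm/s, a higher number than compound 1 by a margin beyond the scatter, while compound 2 `Cc1cc(NC(=O)Nc2cccc(C(N)=O)c2)c2ccccc2n1` gives 2 10^-6 cm/s, far below compound 1. Among the compounds with values here, the only step measured within one change is a 410-fold higher number from compound 2 to compound 3 (2.61 log units; beyond the scatter), a methoxy in place of a carbamoyl on an aromatic carbon.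

Compound 4 `Cc1cc(NC(=O)Nc2ccccc2N)c2ccccc2n1` has not yet been measured in this assay. It differs from compound 1 in one place: 2-aminophenyl in place of 3-methylpyridin-2-yl on an amide-type nitrogen. The entering 2-aminophenyl carries one hydrogen-bond donor where the leaving 3-methylpyridin-2-yl carried none. Within the data shown here, no measured step exchanges one ring for another on the amide-type nitrogen, so the step from compound 2 to compound 3 bears on it only loosely, showing that a change in hydrogen-bonding groups on the aryl ring can move this read-out very strongly. A more modest shift is expected here, a lower number, a 2.5-fold lower number from compound 1 to compound 4 (0.39 log units; beyond the scatter). For compound 4 the estimate is therefore 150 10^-6 cm/s, with a plausible range from 40 10^-6 cm/s to 500 10^-6 cm/s.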

Compound 4, apparent permeability: 300 10^-6 cm/s
Beside the measured number, compound 4's estimate is 2.0-fold (0.30 log units) below it; the measured number falls inside the stated range.
By their numbers in this assay, from the lowest: compound 2; then compounds 4 and 1 (each within the scatter of the next); then compound 3.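

At the amide-type nitrogen, 2-aminophenyl in place of 3-methylpyridin-2-yl gives in this assay a 1.2-fold lower number from compound 1 to compound 4 (0.09 log units; within the scatter), so the two rings stand within the scatter of each other. The earlier compounds shown here offered only a 410-fold higher number from compound 2 to compound 3 (2.61 log units; beyond the scatter), a step on an aromatic carbon, and could not show whether an exchange at this nitrogen would be as large. Here the entering 2-aminophenyl carries 1 hydrogen-bond donor and the leaving 3-methylpyridin-2-yl carries 0, yet the numbers for the pair cannot be told apart, and nothing available explains this result.

The compounds shown do not separate the amine of 2-aminophenyl from the ring that carries it, so a plain phenyl or a methylamino group at the same place would be needed to tell what the amine contributes. They also leave open how a carboxylic acid or a longer chain on this ring would compare in this assay, and whether any such exchange would reach the size of the step between compound 2 and compound 3.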